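The source may hold more compounds than are shown below. What is called first, only, known or untested is meant among the compounds shown, and "the series" means these compounds.

Compound 1 `Cc1cccc(CNc2ncnc3c2ncn3[C@@H]2O[C@H](CO)[C@@H](O)[C@H]2O)c1`: 19100 nM
Compound 2 `COc1cccc(CNc2ncnc3c2ncn3[C@@H]2O[C@H](CO)[C@@H](O)[C@H]2O)c1OC`: > 166000 nM

For the measured compounds named here, compound 1 gives 19100 nM in a functional assay on CCRF-CEM cells (Homo sapiens) for antiproliferative activity, with a stated time of 72 h (a lower number here means a stronger inhibitor, a higher number a weaker inhibitor), and stands as the only compound here with a measured number. Compound 2 reaches only > 166000 nM in this assay, which is a limit rather than a number. Going by the values given here, the single measured step, an at least 8.6-fold higher number from compound 1 to compound 2 (0.93 log units; beyond the scatter), put a 2,3-dimethoxyphenyl in place of the 3-methylphenyl on a saturated chain carbon bound to a nitrogen on an aromatic ring. Compound 3 `OC[C@H]1O[C@@H](n2cnc3c(NCc4ccc(F)c(F)c4F)ncnc32)[C@H](O)[C@@H]1O` is not yet measured; it differs from compound 1 by 2,3,4-trifluorophenyl in place of 3-methylphenyl on a saturated chain carbon bound to a nitrogen on an aromatic ring. Among the compounds with values here, the same 3-methylphenyl leaves, and the one measured step is the only guide, where another substituted phenyl in its place gave at least a modest weakening that ended at the limit of > 166000 nM in this assay, at which 1 of the 2 values shown sits. Compound 3 is therefore expected to show a weakening of roughly a 2.4-fold higher number from compound 1 to compound 3 (0.37 log units; beyond the scatter), with a fair chance of itself reaching the limit. The estimate for compound 3 in this assay is 45000 nM, within a range from 12000 nM to 166000 nM.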

Compound 3, half-maximal inhibitory concentration: 58200 nM
Compound 3: middle estimate off by 1.3-fold (0.11 log units), on the low side, within the range that was stated.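

In this assay, the 2,3,4-trifluorophenyl group gives a measured number, so not every replacement of the 3-methylphenyl on this saturated chain carbon bound to a nitrogen on an aromatic ring ends at a limit; the change brings a 3.0-fold higher number from compound 1 to compound 3 (0.48 log units; beyond the scatter). The two replacements also separate from each other, with an at least 2.8-fold lower number from compound 2 to compound 3 (0.45 log units; beyond the scatter). Both weaken compound 1, which carries the strongest of the three groups shown, while compound 2 alone stands at a limit, not a number: the limit of > 166000 nM in this assay, at which 1 of the 3 values shown sits.

The compounds shown leave open whether a phenyl carrying a single fluorine or a single methoxy group would stay closer to compound 1. They also leave open whether a cyclohexyl group, or a phenyl bearing an amine, could give a lower number than compound 1.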